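The compounds below may be only part of what the source reports. "The series", "measured", "known", "first", "only" and "open" are said of these compounds alone.

Compound 2 `Cc1ccc(/C=C\C(=O)N2N=C(c3ccncc3)OC2c2c[nH]c3ccccc23)cc1` and compound 1 `O=C(/C=C\c1ccccc1O)N1N=C(c2ccncc2)OC1c1c[nH]c2ccccc12` share one core and differ only in the aryl group on the double-bonded chain. In an ADME assay on PANC-1 cells (Homo sapiens) for cytotoxicity, read by MTT assay, with a stated time of 48 h (on this read-out lower numbers stand for stronger inhibition of growth and higher numbers for weaker inhibition of growth), compound 1 gives > 30 ug/mL, which is a limit of the assay rather than a number. In this assay compound 2 likewise gives > 30 ug/mL, again a limit and not a number. The step that the two limits leave unreadable from compound 1 to compound 2 therefore cannot be read, since (the limit of > 30 ug/mL in this assay, at which 2 of the 2 values shown sit). Compound 2 thus stands only at that limit, with no number to set it against. Compound 3 `COc1ccc(/C=C\C(=O)N2N=C(c3ccncc3)OC2c2c[nH]c3ccccc23)cc1` carries methoxy in place of methyl on an aromatic carbon. Going by the values given here, no measured step bears on this change, and the one measured step gives no size in either direction. Compound 3 is therefore expected to remain at the same limit, and the expected step that the limit leaves unreadable from compound 2 to compound 3 is none beyond the scatter. For compound 3 in this assay the estimate is 45 ug/mL, within a range from 20 ug/mL to 120 ug/mL.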

Compound 3, concentration for 50% growth inhibition: > 30 ug/mL
Compound 3 ended at the assay's limit (the forecaster's own chance of this, stated with the estimate: 80%); the middle value is on the limit's open side.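

No step can be read among compound 1, compound 2 and compound 3 in this assay, because each of their values is a limit and not a number: the limit of > 30 ug/mL in this assay, at which 3 of the 3 values shown sit. The compounds shown leave open whether these aryl groups on the double-bonded chain differ at all in this assay.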